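Extending a methyl on an aromatic nitrogen: compound 4 expected

The source may report more compounds than this note shows. Statements on the series, on what has been measured and on what is new or still open speak of the compounds shown alone.

Compound 1 `CN1C(=S)[C@@H](NC(=O)c2nc(Cc3ccccc3)n(C)n2)COc2ccccc21`: 2.5 nM
Compound 2 `CC(C)n1nc(C(=O)N[C@H]2COc3ccccc3N(C)C2=S)nc1Cc1ccccc1`: 360 nM
Compound 3 `CN1C(=S)[C@@H](NC(=O)c2nc(Cc3ccccc3)n(CCCF)n2)COc2ccccc21`: 4760 nM

In a functional assay on HT-29 cells (Homo sapiens) for inhibition, read by luminescence and CellTiter-Glo, with a stated time of 24 h (a higher number here means that more compound is needed for the effect, a lower number that less compound is needed), compound 1 gives the lowest of the three numbers, and both steps away from it, a 140-fold higher number from compound 1 to compound 2 (2.16 log units; beyond the scatter) and a 1900-fold higher number from compound 1 to compound 3 (3.28 log units; beyond the scatter), lie beyond the scatter. Compound 4 `CN1C(=S)[C@@H](NC(=O)c2nc(Cc3ccccc3)n(CCCC#N)n2)COc2ccccc21` differs from compound 1 by 2-cyanoethyl in place of hydrogen on a saturated chain carbon bound to an aromatic nitrogen. The step that bears most directly on this is a 1900-fold higher number from compound 1 to compound 3 (3.28 log units; beyond the scatter), where 2-fluoroethyl replaced hydrogen at the same place, and a 140-fold higher number from compound 1 to compound 2 (2.16 log units; beyond the scatter) points the same way. A large upward step in this assay is therefore expected for compound 4, namely a 1200-fold higher number from compound 1 to compound 4 (3.08 log units; beyond the scatter). Compound 4 is estimated at 3000 nM, with a range from 500 nM to 15000 nM.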

Compound 4, half-maximal effective concentration: 2400 nM
Beside the measured number, compound 4's estimate is 1.3-fold (0.10 log units) above it, within the range that was stated.
By their numbers in this assay, from the lowest: compound 1; then compound 2; then compounds 4 and 3 (each within the scatter of the next).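

In this assay, the change from methyl to 3-cyanopropyl on the aromatic nitrogen is heavily penalised, a 960-fold higher number from compound 1 to compound 4 (2.98 log units; beyond the scatter), and swapping fluoro for cyano on the chain makes no readable difference, a 2.0-fold lower number from compound 3 to compound 4 (0.30 log units; within the scatter). The 3-cyanopropyl group also stands apart from isopropyl, a 6.7-fold higher number from compound 2 to compound 4 (0.82 log units; beyond the scatter), so both longer chains shown give higher numbers than the branched group. Nothing available explains these steps.

The compounds shown leave open whether an unsubstituted propyl group would carry the same penalty. They also leave open how a 3-hydroxypropyl or 3-aminopropyl group would read at this position.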